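Swapping an aryl amine for a benzyl amine

A few compounds are considered here, and "the series" means these few. Any claim that something is new, unique, unknown or untested is made for them only; others in the source may bear on it.

Compound 2 `CSc1ccc(Nc2nc3cc(C(=O)O)ccc3n2Cc2ccccc2C(F)(F)F)cc1` carries a 4-(methylsulfanyl)phenyl group on a nitrogen of the shared core. In an assay on isolated protein for inhibition of kinesin heavy chain isoform 5A (Homo sapiens) (a higher number here means a weaker inhibitor, a lower number a stronger inhibitor), compound 2 gives > 50000 nM, which is a limit of the assay rather than a number. Its close companion, compound 1 `CS(=O)(=O)c1ccc(Nc2nc3cc(C(=O)O)ccc3n2Cc2ccccc2C(F)(F)F)cc1`, differs only by methylsulfonyl in place of methylsulfanyl on an aromatic carbon. In this assay compound 1 gives > 50000 nM, again a limit. The step that the two limits leave unreadable from compound 1 to compound 2 therefore cannot be read, because of the limit of > 50000 nM in this assay, at which 2 of the 2 values shown sit. Compound 3 `COc1ccc(CNc2nc3cc(C(=O)O)ccc3n2Cc2ccccc2C(F)(F)F)cc1` has not yet been measured; the change from compound 2 is 4-methoxybenzyl in place of 4-(methylsulfanyl)phenyl on a nitrogen on an aromatic ring. Among the measured compounds shown here, no measured step bears on this change, since the only step available runs between two limits. The expected step that the limit leaves unreadable from compound 2 to compound 3 is accordingly set at no change beyond the scatter. Compound 3 is estimated at 60000 nM, within 20000 nM to 200000 nM, and most likely the assay will again return only a limit.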

Compound 3, half-maximal inhibitory concentration: > 50000 nM
Compound 3: no number, only a limit (the forecaster's own chance of this, stated with the estimate: 75%); the middle value lies beyond the limit too.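

In this assay compound 3 gives > 50000 nM, again a limit of the assay. The steps to compound 3 from compound 1 and from compound 2 therefore cannot be read: the limit of > 50000 nM in this assay, at which 3 of the 3 values shown sit.

The compounds shown leave open whether any group on this nitrogen gives a readable inhibition, and how large the effect of each swap is.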